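Cyclohexyl in Place of Chlorophenyl: Tolerance Outlook

This account rests on a few compounds, and the source may have more. Where it says the series, first, only, none or still open, it means among the compounds named here.

Compound 1 `Cn1c(-c2ccccc2)cnc1NC(=O)c1ncc[nH]1`: > 100000 nM
Compound 2 `Cn1c(-c2ccccc2)cnc1NC(=O)c1cccc(Cl)c1`: > 50000 nM
Compound 3 `COc1ccc(-c2cnc(NC(=O)c3cccc(C#N)c3)n2C)cc1`: > 100000 nM

Of the compounds shown here, three sharing one core have been tested in a toxicity assay on THP-1 cells (Homo sapiens) for inhibition; a higher number here means that more compound is tolerated, a lower number that less compound is tolerated. Compound 1 gives only a limit there, > 100000 nM. Compound 2 also gives only a limit, > 50000 nM. Compound 3 likewise returns a limit, > 100000 nM. For the measured compounds named here, the single step between measured compounds that differ in one place, a step that the two limits leave unreadable from compound 1 to compound 2, cannot be read in size, since both ends are limits. Compound 2 therefore stands at a limit, as do the two other values, summarised by the limit of > 100000 nM in this assay, at which 2 of the 3 values shown sit, and (the limit of > 50000 nM in this assay, at which 1 of the 3 values shown sits).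

Compound 4, `Cn1c(-c2ccccc2)cnc1NC(=O)C1CCCCC1`, differs from compound 2 by cyclohexyl in place of 3-chlorophenyl on a carbonyl carbon. Going by the values given here, no measured step bears directly on this change, and the one step available is itself unreadable, so there is no ground for expecting a move beyond the scatter in either direction. Compound 4 is therefore expected to give about 80000 nM in this assay, estimated between 30000 nM and 200000 nM. The expected step that the limit leaves unreadable from compound 2 to compound 4 is estimated to stay within the scatter, most likely again reported as a limit.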

Compound 4, half-maximal cytotoxic concentration: > 100000 nM
Compound 4: a limit, no number (the forecaster's own chance of this, stated with the estimate: 75%); middle value at least 1.2-fold (0.09 log units) away from the limit.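

Compound 4 gives only a limit in this assay, as do compound 1 and compound 2, so the steps from compound 2 and compound 1 to compound 4 cannot be read. The compounds shown leave open whether cyclohexyl, 3-chlorophenyl and 1H-imidazol-2-yl on a carbonyl carbon differ at all in this assay.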